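The compounds below may be only part of what the source reports. "The series", "measured", "known", "first", "only" and "open" are said of these compounds alone.

Series notes. Compound 1 `COc1cc(C(c2ccc(O)c(OC)c2)[C@@H](C)C(C)C)ccc1O` serves as the reference point; in a functional assay on HL-60 cells (Homo sapiens) for cytotoxicity, read by WST assay, with a stated time of 48 h (a higher number here means a weaker inhibitor, a lower number a stronger inhibitor), compound 1 gives 20000 nM. Compound 2 `COc1cc(C(c2ccc(O)c(OC)c2)[C@H](CF)C(C)C)ccc1O` gives 19000 nM, and compound 3 `CC[C@H](C(C)C)C(c1ccc(O)c(OC)c1)c1ccc(O)c(OC)c1` gives 16000 nM. Compound 1 sits at one end of these three numbers, but both other compounds stay within the scatter of it: a 1.1-fold lower number from compound 1 to compound 2 (0.02 log units; within the scatter) and a 1.3-fold lower number from compound 1 to compound 3 (0.10 log units; within the scatter). Between the two analogues, a 1.2-fold lower number from compound 2 to compound 3 (0.07 log units; within the scatter). Every step measured so far in this series, including the one that brings in fluorine, leaves the read-out essentially unchanged.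

Compound 4 `COc1cc(C(c2ccc(O)c(OC)c2)[C@H](C)[C@@H](C)CF)ccc1O` has not been measured. Relative to compound 1 the change is 2-(fluoromethyl)-1-methylpropyl in place of 1,2-dimethylpropyl on a saturated chain carbon bound to two aromatic carbons. The measured steps that bear on it are the fluoromethyl swap on the chain (a 1.1-fold lower number from compound 1 to compound 2 (0.02 log units; within the scatter)) and the chain rearrangement (a 1.3-fold lower number from compound 1 to compound 3 (0.10 log units; within the scatter)), each within the scatter. For compound 4 the expected step in this assay is a 1.1-fold lower number from compound 1 to compound 4 (0.02 log units; within the scatter), nothing beyond the scatter. For compound 4 the estimate is 19000 nM, with a range from 9000 nM to 40000 nM.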

Compound 4, half-maximal inhibitory concentration: 45000 nM
Compound 4: middle estimate off by 2.4-fold (0.37 log units), on the low side; measured number outside the range, above it.
By their numbers in this assay, from the lowest: compounds 3, 2 and 1 (each within the scatter of the next); then compound 4.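

In this assay, among these compounds, the 2-(fluoromethyl)-1-methylpropyl group is the first change on the saturated chain carbon bound to two aromatic carbons to go beyond the scatter, with modest steps in all three comparisons (a 2.3-fold higher number from compound 1 to compound 4 (0.35 log units; beyond the scatter)) (a 2.4-fold higher number from compound 2 to compound 4 (0.37 log units; beyond the scatter)) (a 2.8-fold higher number from compound 3 to compound 4 (0.45 log units; beyond the scatter)). This position therefore does not tolerate every chain change equally, and fluorine alone does not account for the shift: compound 2 also carries a fluoromethyl-bearing chain, yet stays within the scatter of compound 1 (a 1.1-fold lower number from compound 1 to compound 2 (0.02 log units; within the scatter)). No measurement at hand explains the shift.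

The compounds shown do not separate the placement of the fluorine from the second defined stereocentre of compound 4. On these data alone, whether a hydroxymethyl or aminomethyl group in place of the fluoromethyl would give a similar step remains open.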